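A ring methyl added to compound 2

The source may report more compounds than this note shows. Statements on the series, on what has been measured and on what is new or still open speak of the compounds shown alone.

Compound 1 `COC(=O)N(C)CC#CCn1cncc1C`: > 100 mg/kg
Compound 2 `CCOC(=O)N(C)CC#CCn1ccnc1`: > 100 mg/kg

In a functional assay on the whole organism for antagonist activity, with Mus musculus as the target (on this read-out higher numbers stand for an effect only at larger amounts of compound and lower numbers for an effect already at smaller amounts), compound 2 gives > 100 mg/kg, which is a limit of the assay and not a number. Compound 1 gives > 100 mg/kg, which is likewise a limit. Within the data shown here, the series so far offers only (the limit of > 100 mg/kg in this assay, at which 2 of the 2 values shown sit), and no measured step is available for comparison.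

Compound 3 `CCOC(=O)N(C)CC#CCn1cncc1C` follows from compound 2 through (methyl in place of hydrogen on an aromatic carbon), with methyl in place of hydrogen on an aromatic carbon. With only the limit of compound 2 at > 100 mg/kg to rest on, no step beyond the scatter is expected in this assay. The expected change is a number no higher from compound 2 to compound 3 (the limit leaves the size open). For compound 3 the estimated value is 100 mg/kg, with an expected range from 40 mg/kg to 200 mg/kg.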

Compound 3, dose for half-maximal effect: 30 mg/kg
The estimate for compound 3 lay 3.3-fold (0.52 log units) above the measured number; measured number below the stated range.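

In this assay, the methyl on the aromatic carbon, next to the ring nitrogen and next to the ring atom that bears a large group, brings the number below the limit, with an at least 3.3-fold lower number from compound 2 to compound 3 (0.52 log units; beyond the scatter). Adding a methyl on the saturated chain carbon bound to an oxygen next to a carbonyl group also matters, with an at least 3.3-fold lower number from compound 1 to compound 3 (0.52 log units; beyond the scatter), so compound 3, which alone carries both methyl groups, is the only compound here with a measured number. The true size of both steps stays open because each starts from a limit and not from a number: the limit of > 100 mg/kg in this assay, at which 2 of the 3 values shown sit.

As far as these compounds go, whether a longer chain on that oxygen would lower the number further remains open. From the compounds shown here alone, it is also open whether a chlorine or an ethyl group on the aromatic carbon would serve in place of the methyl.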